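The compounds below may be only part of what the source reports. "The series", "measured", "known", "first", "only" and "open" are said of these compounds alone.

For the series in a functional assay on brain (Rattus norvegicus, strain Wistar) for inhibition (a lower number here means a stronger inhibitor, a higher number a weaker inhibitor), compound 1 (`CCCCc1ccc(-c2c(C)[nH]c(=O)n2C)cc1`) gives 10700 nM and compound 2 (`CCCCc1ccc(-c2c(C)[nH]c(=O)n2C(C)C)cc1`) gives 10700 nM with no change at the digits printed from compound 1 to compound 2 (within the scatter) between them. Compound 3 (`CCCCc1ccc(-c2c(C)[nH]c(=O)n2C2CCCCC2)cc1`) stands at 27100 nM as the highest number of the three, which makes it the weakest inhibitor measured so far. The measured steps that bear on the next change are a 2.5-fold higher number from compound 1 to compound 3 (0.40 log units; beyond the scatter) and a 2.5-fold higher number from compound 2 to compound 3 (0.40 log units; beyond the scatter) at the same nitrogen, both modest. Compound 4 (`CCCCc1ccc(-c2c(C)[nH]c(=O)n2-c2ccccc2)cc1`) carries phenyl in place of cyclohexyl on an aromatic nitrogen and is not yet measured. No aromatic group at this position has a measured value, so these steps give only a rough scale for the change. Only a small move toward a lower number is expected, and the estimated size is a 1.7-fold lower number from compound 3 to compound 4 (0.23 log units; within the scatter) with no larger shift foreseen. The estimated value for compound 4 is 16000 nM within an expected range from 7000 nM to 35000 nM on this evidence.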

Compound 4, half-maximal inhibitory concentration: 16600 nM
Compound 4: the middle estimate sits 1.0-fold (0.02 log units) below what was measured; measured number inside the range.
By their numbers in this assay, from the lowest: compounds 1, 2, 4 and 3 (each within the scatter of the next, the first and the last beyond it).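

In this assay, among these compounds, the first aromatic group at this nitrogen gives a 1.6-fold lower number from compound 3 to compound 4 (0.21 log units; within the scatter), while the comparisons with the smaller groups give a 1.6-fold higher number from compound 2 to compound 4 (0.19 log units; within the scatter) and a 1.6-fold higher number from compound 1 to compound 4 (0.19 log units; within the scatter), so compound 4 cannot be told apart from any of the other three compounds. Replacing the non-aromatic six-membered carbon ring with the aromatic one, at an unchanged heavy-atom count, therefore gives no readable change, and the steps into cyclohexyl from methyl and isopropyl remain the only ones here beyond the scatter. Nothing available here explains these numbers. Going by these compounds, whether a pyridyl ring, a benzyl group or a phenyl ring carrying an amine or a carboxylic acid at this nitrogen would move the number beyond the scatter remains open.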